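This account rests on a few compounds, and the source may have more. Where it says the series, first, only, none or still open, it means among the compounds named here.

Compound 3 `O=C1/C(=C/c2ccc(O)cc2)CCC/C1=C\c1ccc([N+](=O)[O-])cc1` carries a hydroxy group on one aromatic ring and a nitro group on the other. In a functional assay on HSG cells (Homo sapiens) for cytotoxicity (a lower number here means that less compound is tolerated, a higher number that more compound is tolerated), compound 3 gives only a limit, > 400000 nM. Compound 2 `O=C1/C(=C/c2ccc(Cl)cc2)CCC/C1=C\c1ccc([N+](=O)[O-])cc1`, with chloro in place of that hydroxy, gives 15000 nM, and compound 1 `COc1ccc(/C=C2\CCC/C(=C\c3ccc([N+](=O)[O-])cc3)C2=O)cc1OC`, with two methoxy groups on that ring, gives 13000 nM. Among the measured compounds shown here, the single measured change at this position, an at least 26-fold higher number from compound 2 to compound 3 (1.42 log units; beyond the scatter), ends at the limit (the limit of > 400000 nM in this assay, at which 1 of the 3 values shown sits). Compound 4 `COc1ccc(/C=C2\CCC/C(=C\c3ccc([N+](=O)[O-])cc3)C2=O)cc1` is compound 3 with methyl in place of hydrogen on an oxygen on an aromatic ring. Compound 1 already shows 13000 nM with methoxy groups in place, and that value guides the expectation here. A large downward step is therefore expected, an at least 26-fold lower number from compound 3 to compound 4 (1.42 log units; beyond the scatter). Compound 4 is expected to give about 15000 nM, between 5000 nM and 60000 nM.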

Compound 4, half-maximal cytotoxic concentration: > 400000 nM
Compound 4 was reported as a limit (the forecaster's own chance of this, stated with the estimate: 10%); middle value at least 26-fold (1.42 log units) from the limit.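

In this assay compound 4 gives a limit, > 400000 nM. A free hydroxy is therefore not required for a high number here: a single methoxy also gives one, with an at least 26-fold higher number from compound 2 to compound 4 (1.42 log units; beyond the scatter), while the loss of the second methoxy group counts for just as much, with an at least 30-fold higher number from compound 1 to compound 4 (1.48 log units; beyond the scatter). The step from compound 3 to compound 4 cannot be read, as both values are limits: the limit of > 400000 nM in this assay, at which 2 of the 4 values shown sit.

Going by these compounds, how far compound 3 and compound 4 truly lie past that limit remains open. So does whether an amine or a carboxylic acid on this ring would keep the number high.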